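Swapping a fluorophenyl arm for pyrrole in a chalcone sulfonylurea

The compounds below may be only part of what the source reports. "The series", "measured", "known", "first", "only" and "open" are said of these compounds alone.

Measured so far:
compound 1 `COc1ccc(/C=C/C(=O)c2ccccc2NC(=O)NS(=O)(=O)c2ccc(C)cc2)cc1` — 28.1 ug/mL
compound 2 `Cc1ccc(S(=O)(=O)NC(=O)Nc2ccccc2C(=O)/C=C/c2ccc(F)cc2)cc1` — 3.96 ug/mL

In an ADME assay on the whole organism for cytotoxicity, with Artemia salina as the target, with a stated time of 24 h (on this read-out higher numbers stand for an effect only at larger amounts of compound and lower numbers for an effect already at smaller amounts), compound 2 gives the lower of the two numbers, and compound 1 the higher; the step of a 7.1-fold lower number from compound 1 to compound 2 (0.85 log units; beyond the scatter) separates them and lies beyond the scatter. Compound 3 `Cc1ccc(S(=O)(=O)NC(=O)Nc2ccccc2C(=O)/C=C/c2ccc[nH]2)cc1` has not yet been measured in this assay. It differs from compound 2 in one place: 1H-pyrrol-2-yl in place of 4-fluorophenyl on a double-bonded chain carbon bound to a double-bonded chain carbon. For the measured compounds named here, only one measured step exists, and it changes the same distant ring in a different way, exchanging one substituent for another while keeping the six-membered ring; the move to compound 3 replaces that ring altogether. That single step shows the far end of the molecule can shift the read-out by a modest but clear amount, so a change of similar size is expected here, with the direction uncertain; a number somewhat higher than that of compound 2 is estimated, since compound 1 and compound 2 together mark the region in which this series has landed so far. For compound 3 the expected step is a 2.5-fold higher number from compound 2 to compound 3 (0.40 log units; beyond the scatter). The estimate for compound 3 in this assay is 10 ug/mL, with a range from 2.5 ug/mL to 40 ug/mL.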

Compound 3, concentration for half-maximal effect: 32.1 ug/mL
Compound 3: middle estimate off by 3.2-fold (0.51 log units), on the low side; measured number inside the range.
By their numbers in this assay, from the lowest: compound 2; then compounds 1 and 3 (each within the scatter of the next).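

In this assay, the step of an 8.1-fold higher number from compound 2 to compound 3 (0.91 log units; beyond the scatter) shows that replacing the whole 4-fluorophenyl ring at this position, rather than only changing its substituent, also shifts the read-out clearly. The other comparison adds something new: the step of a 1.1-fold higher number from compound 1 to compound 3 (0.06 log units; within the scatter) puts 1H-pyrrol-2-yl and 4-methoxyphenyl level, so two quite different rings, one five-membered with a hetero atom and one six-membered of carbon only, cannot be told apart here, and compound 2 alone stands apart, with the lowest number of the three. No measurement available here explains why 4-fluorophenyl differs from the other two groups.

For the compounds shown here, with only three groups compared, it remains open whether the low number of compound 2 is tied to the fluoro group itself or would also appear with a chloro group, an amine or a plain hydrogen in its place on the same ring. It is also unclear how other five-membered rings would behave at this position, for example a furan or a thiophene, and so whether 1H-pyrrol-2-yl is typical of such rings.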